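Methylsulfanyl in Place of Methylsulfonyl on a Shared Core

This account rests on a few compounds, and the source may have more. Where it says the series, first, only, none or still open, it means among the compounds named here.

In an assay on CHO cells for binding affinity to Alpha-2C adrenergic receptor (Homo sapiens), read by radioligand binding (a higher number here means a weaker inhibitor, a lower number a stronger inhibitor), compound 1 `CSc1ccc(C)cc1NCC1=NCCN1` gives 200 nM. Compound 2 `CS(=O)(=O)c1ccc(F)cc1NCC1=NCCN1` is known only through a limit of the assay, < 5020 nM, not a single number. The measured evidence is thin: the limit of < 5020 nM in this assay, at which 1 of the 2 values shown sits. Compound 3 `CSc1ccc(F)cc1NCC1=NCCN1` differs from compound 2 by methylsulfanyl in place of methylsulfonyl on an aromatic carbon. Compound 2 stands at a limit, so no step size can be read from it directly. The step is expected to be a step that the limit leaves unreadable from compound 2 to compound 3, in the direction of tighter binding. The estimate for compound 3 in this assay is 250 nM, with a likely range from 80 nM to 800 nM.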

Compound 3, inhibition constant: 115 nM
Compound 3: middle estimate off by 2.2-fold (0.34 log units), on the high side, within the range that was stated.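

For compound 2, the methylsulfonyl compound, this assay gives only a limit (< 5020 nM). With methylsulfanyl kept on the aromatic carbon, fluoro in place of methyl shows a 1.7-fold lower number from compound 1 to compound 3 (0.24 log units; within the scatter) and so does not separate these two compounds in this assay. The size of the change from methylsulfonyl to methylsulfanyl on this aromatic carbon cannot be read: the limit of < 5020 nM in this assay, at which 1 of the 3 values shown sits.

From the compounds shown here alone, what an ethylsulfanyl group or a methoxy group would do at this aromatic carbon stays open. So does the effect of a longer chain on the sulfur.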